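Carboxy for hydroxymethyl on two related cores

This account rests on a few compounds, and the source may have more. Where it says the series, first, only, none or still open, it means among the compounds named here.

Compound 1 `Cn1nc(Cc2nnc(SCC(=O)Nc3ccc(Cl)cc3Cl)n2CCCO)c2ccccc2c1=O` and compound 2 `Cn1nc(Cc2nnc(SCC(=O)Nc3ccc(Cl)cc3Cl)n2CCC(=O)O)c2ccccc2c1=O` share one core; compound 3 `Cn1c(Cc2nn(CCCO)c(=O)c3ccccc23)nnc1SCC(=O)Nc1ccc(Cl)cc1Cl` and the unmeasured compound 4 `Cn1c(Cc2nn(CCC(=O)O)c(=O)c3ccccc23)nnc1SCC(=O)Nc1ccc(Cl)cc1Cl` share another, built from the same atoms joined differently. The difference between the two cores is not broken down here. Within each pair the change is the same: carboxy in place of hydroxymethyl on a saturated chain carbon, two bonds along the chain from an aromatic nitrogen in the first pair and carboxy in place of hydroxymethyl on a saturated chain carbon, two bonds along the chain from an aromatic nitrogen in the second, the place reading the same word for word in both, so the two are the same kind of change on different cores.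

In an assay on NK92 cells for inhibition of interleukin-15 (Homo sapiens), read by AlphaScreen, with stated times of 30 min and 1 h (on this read-out higher numbers stand for weaker inhibition and lower numbers for stronger inhibition), compound 1 gives only a limit, > 30000 nM. Compound 2 gives only a limit as well in this assay, > 30000 nM. The measured step that the two limits leave unreadable from compound 1 to compound 2 therefore has no readable size, both ends resting at the limit of > 30000 nM in this assay, at which 2 of the 3 values shown sit. Within the data shown here, compound 3 is the one compound with a number in this assay, 30000 nM, and its value shows weak inhibition at best.

Among the measured compounds shown here, for compound 4 in this assay the expectation is a step of a 1.3-fold higher number from compound 3 to compound 4 (0.12 log units; within the scatter), an essentially flat move, since the only measured instance of the same change gave a step that the two limits leave unreadable from compound 1 to compound 2 with no readable size and no sign of a gain. Compound 4 is therefore estimated at 40000 nM in this assay, with a range from 15000 nM to 120000 nM, and with a high chance that the assay returns only a limit rather than a number.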

Compound 4, half-maximal inhibitory concentration: > 30000 nM
Compound 4: only a limit was reported; the forecaster's own chance of this, stated with the estimate: 70%; the middle value does not contradict the limit.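

In this assay compound 4 gives only a limit, > 30000 nM. Carboxy in place of hydroxymethyl on the core of compound 3 gives a number no lower from compound 3 to compound 4 (the limit leaves the size open), and the same change on the core of compound 1 ends in two limits, so neither step can be read for size and neither core shows a gain. The change therefore carries from one core to the other only in this weak sense; no pair gives two numbers, and whether the change has the same size on both cores stays unknown: the limit of > 30000 nM in this assay, at which 3 of the 4 values shown sit.

Left open is whether anything on either core can give a number clearly stronger than compound 3, which at 30000 nM is the only number in the set and marks weak inhibition at best. Also open, from the compounds shown here alone, is whether an amine or a primary amide at the end of the same chain, or a longer chain, would bring either core into the readable range of this assay, which a readable comparison of this change would need.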